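The source may hold more compounds than are shown below. What is called first, only, known or untested is meant among the compounds shown, and "the series" means these compounds.

Measured compounds in a functional assay on the whole organism (Tail, strain ICR) with Mus musculus as the target, in the tail flick test, with a stated time of 60 min, at a dose of 25 umol/kg by the oral route; a higher number here means a stronger effect of the compound at the dose given, a lower number a weaker effect:
Compound 1 `O=C(CN(c1nc(Cl)nc2[nH]cnc12)C1CC1)N[C@@H](CCC(=O)OCc1ccccc1)C(=O)OCc1ccccc1`: 53.7%
Compound 2 `NCCCC[C@H](NC(=O)CN(c1nc(Cl)nc2[nH]cnc12)C1CC1)C(=O)OCc1ccccc1`: 41.2%
Compound 3 `O=C(CN(c1ncnc2c1ncn2C1CCCCO1)C1CC1)N[C@@H](CO)C(=O)OCc1ccccc1`: 46.7%

Compound 3 stands second highest of the three numbers shown in this assay. Its nearest neighbour is compound 2, whose value lies within the scatter of repeated measurements, and the same holds for compound 1, the furthest of the three; on these numbers alone the three compounds cannot be separated with confidence.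

Compound 4 `CSCC[C@H](NC(=O)CN(c1ncnc2c1ncn2C1CCCCO1)C1CC1)C(=O)OCc1ccccc1` has not yet been measured. It differs from compound 3 in a single place: (methylsulfanyl)methyl in place of hydroxy on a saturated chain carbon, two bonds along the chain from an amide-type nitrogen and a carbonyl carbon. Going by the values given here, only one measured step is available, a number 12.5 percentage points lower from compound 1 to compound 2 (beyond the scatter), and it concerns a different position, three bonds along the chain rather than two, and different groups, so it does not speak directly to the change made here. Lacking a step that bears on it, the expectation for compound 4 rests on compound 3 alone: the step of a number 0.3 percentage points higher from compound 3 to compound 4 (within the scatter) is expected to remain within the scatter of this assay. Compound 4 is therefore estimated at 47%, with a range from 32% to 62%.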

Compound 4, a percentage reported as activity, at one dose (the size of the read-out at that dose, not a potency): 41%
Beside the measured number, compound 4's estimate is 6 percentage points above it, and the stated range covers the measured number.
By their numbers in this assay, from the lowest: compounds 4, 2, 3 and 1 (each within the scatter of the next, the first and the last beyond it).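

In this assay, the first step read at this position, a number 5.7 percentage points lower from compound 3 to compound 4 (within the scatter), shows that on this saturated chain carbon, two bonds along the chain from an amide-type nitrogen and a carbonyl carbon, hydroxy can give way to (methylsulfanyl)methyl without a difference that stands clear of the scatter. The change is not a trivial one on paper: hydroxy, with 1 heavy atom and 1 hydrogen-bond donor, leaves, and (methylsulfanyl)methyl, with 3 heavy atoms, one of them sulfur, and 0 hydrogen-bond donors, enters, so this pair gives no sign that the donor of hydroxy is needed for the effect at this dose. No measurement offered here explains the result, so it stands as an observation only.

Going by these compounds, whether this tolerance extends to other groups stays open, since an amine or a carboxylic acid on the same carbon, or a chain longer than 2-(methylsulfanyl)ethyl, could behave differently. One pair read at a single dose also cannot show whether the two groups would still match at other doses, or whether the same change would hold on the core of compound 1.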